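This account rests on a few compounds, and the source may have more. Where it says the series, first, only, none or still open, it means among the compounds named here.

Measured in a functional assay on MDA-MB-231 cells (Homo sapiens) for antiproliferative activity, read by MTT assay, with a stated time of 72 h; a higher number here means a weaker inhibitor, a lower number a stronger inhibitor:
- compound 1 `COc1cc(OC)cc(-c2cccc(NC(=O)CCc3cccc4c3B(O)OC4)c2)c1` gives 40 nM
- compound 2 `CSc1ccc(-c2cccc(NC(=O)CCc3cccc4c3B(O)OC4)c2)cc1` gives 140 nM

Of these two, compound 2 (140 nM) holds the higher number. Compound 3 `O=C(CCc1cccc2c1B(O)OC2)Nc1cccc(-c2ccc(C(F)(F)F)cc2)c1` carries trifluoromethyl in place of methylsulfanyl on an aromatic carbon, para to a large group (trifluoromethyl in place of methylsulfanyl on an aromatic carbon). Among the measured compounds shown here, one measured step bears on this change: a 3.5-fold higher number from compound 1 to compound 2 (0.54 log units; beyond the scatter), where the aryl group also differs. It gives size only, not direction. A modest step or none beyond the scatter is expected in this assay, leaning towards a higher number. The expected step is a 1.4-fold higher number from compound 2 to compound 3 (0.15 log units; within the scatter). For compound 3 the estimate is 200 nM, with an expected range of 70 nM to 600 nM.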

Compound 3, half-maximal inhibitory concentration: 510 nM
Compound 3: middle estimate off by 2.6-fold (0.41 log units), on the low side; the measured number falls inside the stated range.
By their numbers in this assay, from the lowest: compound 1; then compound 2; then compound 3.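

In this assay, trifluoromethyl in place of methylsulfanyl on an aromatic carbon, para to a large group, gives a 3.6-fold higher number from compound 2 to compound 3 (0.56 log units; beyond the scatter). With the rest of the structure unchanged, this isolates a change at this one position that lies beyond the scatter. Replacing 3,5-dimethoxyphenyl with 4-(trifluoromethyl)phenyl gives a 13-fold higher number from compound 1 to compound 3 (1.11 log units; beyond the scatter), a wider span across the aryl group than the earlier pair showed.

From the compounds shown here alone, whether a nitrile or an amine at this position would give a number nearer compound 2 or compound 3 remains open. No measurement shown here explains the size of either step.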